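A few compounds are considered here, and "the series" means these few. Any claim that something is new, unique, unknown or untested is made for them only; others in the source may bear on it.

In a functional assay on SiHa cells (Homo sapiens) for cytotoxicity, read by MTT assay, with a stated time of 48 h (a lower number here means a stronger inhibitor, a higher number a weaker inhibitor), compound 1 `CCCCCCCCNC(=O)[C@@H](NC(=O)c1cccs1)[C@@H](C)O` gives 91900 nM. For the measured compounds named here, compound 2 `CCCCCCCCCCCCCCCCCCNC(=O)[C@@H](NC(=O)c1cccs1)[C@@H](C)O` gives 117000 nM in this assay; this is the higher of the two numbers seen so far, yet the one measured step, a 1.3-fold higher number from compound 1 to compound 2 (0.10 log units; within the scatter), concerns only the chain, decyl in place of hydrogen on a saturated chain carbon, eight bonds along the chain from an amide-type nitrogen. Compound 3 `CCCCCCCCCCCCCCCCCCNC(=O)[C@@H](NS(=O)(=O)c1ccc(C)cc1)[C@@H](C)O` has not yet been measured. It differs from compound 2 in a single place, on an amine nitrogen whose other neighbour is a saturated chain carbon: (4-methylphenyl)sulfonyl in place of (thiophen-2-yl)carbonyl on an amine nitrogen. Going by the values given here, no measured step covers an exchange of this kind, and the one step that was measured changed a different part of the molecule and stayed within the scatter. There is therefore no ground to expect a step beyond the scatter in this assay in either direction. Compound 3 is expected to give 100000 nM in this assay, with a range from 40000 nM to 250000 nM. The expected step of a 1.2-fold lower number from compound 2 to compound 3 (0.07 log units; within the scatter) is thus estimated to lie within the scatter.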

Compound 3, half-maximal inhibitory concentration: 29800 nM
Compound 3: the middle estimate sits 3.4-fold (0.53 log units) above what was measured; measured number below the stated range.
By their numbers in this assay, from the lowest: compound 3; then compounds 1 and 2 (each within the scatter of the next).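

In this assay, for the compounds shown here, the group on the amine nitrogen is the first place where a single change moves the number beyond the scatter: (4-methylphenyl)sulfonyl in place of (thiophen-2-yl)carbonyl gives a 3.9-fold lower number from compound 2 to compound 3 (0.59 log units; beyond the scatter), whereas the chain change gave only a 1.3-fold higher number from compound 1 to compound 2 (0.10 log units; within the scatter). This single exchange replaces the ring and the link to the nitrogen together, so the step cannot be assigned to either part alone. Nothing available explains why the number falls.

A benzoyl group or a (thiophen-2-yl)sulfonyl group on the same nitrogen would help to separate the ring from the link. From the compounds shown here alone, it also remains open whether (4-methylphenyl)sulfonyl gives a similar step on the shorter chain of compound 1.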